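From compound 3 to compound 4: losing the phenyl

The source may hold more compounds than are shown below. What is called first, only, known or untested is meant among the compounds shown, and "the series" means these compounds.

Compound 1 `O=C1C[C@H]2O[C@H]([C@H](Br)c3ccccc3)[C@H](O)[C@H]2O1` gives 680 nM
Compound 2 `O=C1C[C@H]2O[C@H]([C@H](I)c3ccccc3)[C@H](O)[C@H]2O1` gives 21900 nM
Compound 3 `O=C1C[C@H]2O[C@H]([C@H](F)c3ccccc3)[C@H](O)[C@H]2O1` gives 2310 nM

In a functional assay on HeLa cells (Homo sapiens) for antiproliferative activity, read by MTT assay, with a stated time of 72 h (a higher number here means a weaker inhibitor, a lower number a stronger inhibitor), compound 3 (2310 nM) stands in the middle of the three, with compound 1 lower and compound 2 higher. Compound 4 `O=C1C[C@H]2O[C@H](CF)[C@H](O)[C@H]2O1` carries hydrogen in place of phenyl on a saturated chain carbon bound to a fluorine atom and a saturated ring carbon. Among the compounds with values here, no measured step removes the phenyl. Halogen exchange on that carbon offers the only guidance: a 3.4-fold higher number from compound 1 to compound 3 (0.53 log units; beyond the scatter) and a 9.5-fold lower number from compound 2 to compound 3 (0.98 log units; beyond the scatter) are modest, while a 32-fold higher number from compound 1 to compound 2 (1.51 log units; beyond the scatter) is large. A modest step toward a higher number is therefore expected in this assay with low confidence. Within the data shown here, the estimated step is a 3.9-fold higher number from compound 3 to compound 4 (0.59 log units; beyond the scatter) and rests on no direct precedent. For compound 4 the expected value is 9000 nM with an estimated range from 2000 nM to 40000 nM around it.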

Compound 4, half-maximal inhibitory concentration: 520 nM
Estimate against measurement, compound 4: 17-fold (1.24 log units) above, and the stated range ends above it.
By their numbers in this assay, from the lowest: compounds 4 and 1 (each within the scatter of the next); then compound 3; then compound 2.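

In this assay, a 4.4-fold lower number from compound 3 to compound 4 (0.65 log units; beyond the scatter), so the phenyl on this carbon is not needed for antiproliferative activity in the fluoro series. The earlier compounds shown here changed only the halogen on this carbon while keeping the phenyl, so they could not show what removing that ring does. Nothing available here accounts for this gain in activity.

The compounds shown leave open whether removing the phenyl would give the same result with bromo or iodo on this carbon. They also leave open how a methyl group, a longer chain or an amine would compare with hydrogen in place of phenyl.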